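The source may report more compounds than this note shows. Statements on the series, on what has been measured and on what is new or still open speak of the compounds shown alone.

Measured compounds:
compound 1 `Cc1nn(C)c2c1C(c1ccccc1Cl)=NCC(=O)N2` – 2.5 mg/kg
compound 2 `CCc1nn(C)c2c1C(c1ccccc1Cl)=NCC(=O)N2` – 2.5 mg/kg
compound 3 `CC(C)c1nn(C)c2c1C(c1ccccc1Cl)=NCC(=O)N2` – > 40 mg/kg

In a functional assay on the whole organism (strain Holtzman) with Rattus norvegicus as the target (on this read-out higher numbers stand for an effect only at larger amounts of compound and lower numbers for an effect already at smaller amounts), compound 3 gives only a limit of the assay, > 40 mg/kg, and no number (the limit of > 40 mg/kg in this assay, at which 1 of the 3 values shown sits). It therefore stands apart from compound 1 and compound 2, which both give measured values. The step from compound 1 to compound 2, a methyl in place of hydrogen on a saturated chain carbon bound to an aromatic carbon, shows no change at the digits printed from compound 1 to compound 2 (within the scatter). The steps into compound 3 are large: an at least 16-fold higher number from compound 1 to compound 3 (1.20 log units; beyond the scatter) and an at least 16-fold higher number from compound 2 to compound 3 (1.20 log units; beyond the scatter).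

Compound 4 `CCCc1nn(C)c2c1C(c1ccccc1Cl)=NCC(=O)N2` is the next member; it and compound 3 have the same atoms, joined differently: propyl in place of isopropyl on an aromatic carbon. Isopropyl leaves, propyl enters. The bearing steps are those into compound 3, where isopropyl on this aromatic carbon carried the number to the limit, whereas the chains of compound 1 and compound 2 did not. Propyl is an unbranched chain like that of compound 2, so in this assay compound 4 is expected to come back from the limit, a step of an at least 8.0-fold lower number from compound 3 to compound 4 (0.90 log units; beyond the scatter), with a number near those of compound 1 and compound 2 but with a wide range, since a longer chain has not been measured. The estimate for compound 4 is 5 mg/kg, from 2 mg/kg to 20 mg/kg.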

Compound 4, minimum effective dose: > 40 mg/kg
Compound 4 ended at the assay's limit; the forecaster's own chance of this, stated with the estimate: 25%; at least 8.0-fold (0.90 log units) between middle value and limit.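

Working notes on the chain at this aromatic carbon: in this assay, branching alone no longer accounts for the loss seen with isopropyl, since the unbranched propyl of compound 4 shows an at least 16-fold higher number from compound 2 to compound 4 (1.20 log units; beyond the scatter) and an at least 16-fold higher number from compound 1 to compound 4 (1.20 log units; beyond the scatter). Among the compounds shown, the methyl of compound 1 and the ethyl of compound 2 give measured values, while the propyl and isopropyl chains, each with 3 heavy atoms, do not, so the sharp change here falls between ethyl and these two isomeric chains. Compound 3 and compound 4 each give only a limit, so the step between them cannot be read and the two chains cannot be ranked against each other, and the limit now covers both: the limit of > 40 mg/kg in this assay, at which 2 of the 4 values shown sit.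

As far as these compounds go, how far the true values of compound 3 and compound 4 lie beyond that limit remains open. Also open, from the compounds shown here alone, is whether a longer chain such as butyl, a small ring such as cyclopropyl, or a chain ending in an amine or a carboxylic acid at this aromatic carbon would stay at the limit or give a measured value.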